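Methyl for hydrogen, repeated across two cores

The source may hold more compounds than are shown below. What is called first, only, known or untested is meant among the compounds shown, and "the series" means these compounds.

Compound 1 `Cc1ccc(C(=O)NNC(=S)Nc2csc(-c3ccccc3)c2)cc1` is the parent of the first pair. In a functional assay on SK-MEL-28 cells (Homo sapiens) for inhibition, read by colorimetric assay and MTT assay, with a stated time of 72 h (on this read-out lower numbers stand for stronger inhibition and higher numbers for weaker inhibition), compound 1 gives 40000 nM. Among the compounds with values here, compound 2 `Cc1ccc(C(=O)NNC(=S)Nc2csc(-c3ccc(C)cc3)c2)cc1` carries the single change methyl in place of hydrogen on an aromatic carbon on the core of compound 1; in this assay compound 2 gives 44000 nM. The step is a 1.1-fold higher number from compound 1 to compound 2 (0.04 log units; within the scatter), so within this pair the methyl leaves the read-out essentially where it was.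

Compound 3 `COc1ccc(C(=O)NNC(=S)Nc2csc(-c3ccccc3)c2)cc1OC` rests on a different core; the difference between the core of compound 3 and the core of compound 1 is not broken down here. In this assay compound 3 gives 28000 nM. This number and those of compound 1 and compound 2 all lie within the scatter of one another, so no order among the three measured compounds can be read from them.

Compound 4 `COc1ccc(C(=O)NNC(=S)Nc2csc(-c3ccc(C)cc3)c2)cc1OC` has not yet been measured. It differs from compound 3 by methyl in place of hydrogen on an aromatic carbon, and the place where the methyl enters reads the same as in the first pair, so this is the same change made on the second core. Within the data shown here, the only guide to its effect is the one measured occurrence, which stayed within the scatter. The step from compound 3 to compound 4 is therefore expected to be a 1.1-fold higher number from compound 3 to compound 4 (0.04 log units; within the scatter), resting on the earlier 1.1-fold higher number from compound 1 to compound 2 (0.04 log units; within the scatter) seen in the first pair. Compound 4 is accordingly estimated at 31000 nM, with an expected range from 15000 nM to 65000 nM.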

Compound 4, half-maximal inhibitory concentration: 19000 nM
For compound 4 the middle estimate is 1.6-fold (0.21 log units) above the measured one; the measured number falls inside the stated range.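

In this assay, replacing phenyl with 4-methylphenyl on the second core gives a 1.5-fold lower number from compound 3 to compound 4 (0.17 log units; within the scatter), so here too the methyl leaves the read-out within the usual scatter. Set beside the first pair, the two steps cannot be told apart: the same change on two cores in this assay, a 1.1-fold higher number (0.04 log units; within the scatter) from compound 1 to compound 2 and a 1.5-fold lower number (0.17 log units; within the scatter) from compound 3 to compound 4, 1.6-fold (0.21 log units) apart, within the scatter of two such steps. Within the data shown here, this supports only a limited reading, that on these two cores the methyl produces no step beyond the scatter, while the opposite printed directions carry no meaning and neither pair shows a real methyl effect that could be said to transfer from one core to the other.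

The compounds shown leave open whether any group at this position, such as a chlorine, a methoxy group, an amine, a carboxylic acid or a longer chain, would move the number beyond the scatter on either core. They also leave open whether a step of that kind would keep its size from one core to the other, which is the test that two near-silent methyl pairs cannot provide.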